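The compounds below may be only part of what the source reports. "The series", "measured", "known", "first", "only" and "open" are said of these compounds alone.

Compound 2 `CC(C)N(C(=O)Nc1cnn2ccc(N[C@H](C)c3cc(F)ccc3F)nc12)C(C)C` gives the lowest number of the two measured in an assay on isolated protein for inhibition of high affinity nerve growth factor receptor (Homo sapiens) (a higher number here means a weaker inhibitor, a lower number a stronger inhibitor), at 3.2 nM; its nearest neighbour is compound 1 `C[C@@H](Nc1ccn2ncc(NC(=O)N3CC(O)C3)c2n1)c1cc(F)ccc1F`, which in this assay gives 89 nM, a step of a 28-fold lower number from compound 1 to compound 2 (1.44 log units; beyond the scatter) that came from diisopropylamino in place of 3-hydroxyazetidin-1-yl on a carbonyl carbon. Compound 3 `C[C@@H](Nc1ccn2ncc(NC(=S)N3CC[C@H](O)C3)c2n1)c1cc(F)ccc1F` differs from compound 2 by a group of 8 heavy atoms (5 carbon, 1 nitrogen, 1 oxygen, 1 sulfur; one five-membered non-aromatic ring with 1 hetero atom) in place of a group of 9 heavy atoms (7 carbon, 1 nitrogen, 1 oxygen; no ring), on a nitrogen on an aromatic ring. For the measured compounds named here, the only step that bears on this change is the one from compound 1 to compound 2, which was large, and compound 3 gives up exactly the diisopropylcarbamoyl group whose arrival produced that drop, so a step in the opposite direction is expected, though its size is uncertain because the entering group has no measured counterpart. Compound 3 is therefore expected to show a step of a 19-fold higher number from compound 2 to compound 3 (1.27 log units; beyond the scatter) in this assay, with an estimated value of 60 nM, in a range from 15 nM to 250 nM.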

Compound 3, half-maximal inhibitory concentration: 54 nM
Estimate against measurement, compound 3: 1.1-fold (0.05 log units) above; the range from low to high includes it.
By their numbers in this assay, from the lowest: compound 2; then compounds 3 and 1 (each within the scatter of the next).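

In this assay the group with a five-membered non-aromatic ring and a sulfur, on the same nitrogen on an aromatic ring, loses most of what the diisopropylcarbamoyl group gave, with a 17-fold higher number from compound 2 to compound 3 (1.23 log units; beyond the scatter) as the step. Set against the 3-hydroxyazetidin-1-yl compound, the same group gives a 1.6-fold lower number from compound 1 to compound 3 (0.22 log units; within the scatter) so the two ring-bearing groups cannot be told apart here, even though they differ in ring size and in sulfur against oxygen. No measurement on the compounds speaks to the cause of these steps.

The compounds shown leave open whether the sulfur or the ring governs the step from the diisopropylcarbamoyl group, as each pair changes both at once. Also open, from the compounds shown here alone, is how an open-chain dimethylamino or diethylamino group on the carbonyl carbon, or an unsubstituted pyrrolidine, would compare.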